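The source may hold more compounds than are shown below. What is called first, only, known or untested is meant among the compounds shown, and "the series" means these compounds.

In an assay on isolated protein for inhibition of DNA topoisomerase 1 (Homo sapiens), with a stated time of 15 min (a lower number here means a stronger inhibitor, a higher number a weaker inhibitor), the measured compounds are:
compound 1 `O=C(O)c1cn(Cc2ccc(-c3ccccc3)cc2)c2cc(N3CC4CNCC4C3)c(F)cc2c1=O`, which gives 33300 nM
compound 2 `CNC[C@@H]1CCN(c2cc3c(cc2F)c(=O)c(C(=O)O)cn3Cc2ccc(-n3cccn3)cc2)C1`, which gives only > 200000 nM
compound 3 `COc1c(N2CC[C@@H](CN)C2)c(F)cc2c(=O)c(C(=O)NO)cn(Cc3ccc(-c4ccccc4)cc3)c12`, which gives 35900 nM

Compound 2 stands apart from the other two: its value is a limit of this assay and not a number, as the limit of > 200000 nM in this assay, at which 1 of the 3 values shown sits, records. Compound 1 and compound 3 give numbers within the usual scatter of each other.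

Compound 4 `O=C(O)c1cn(Cc2ccc(-n3cccn3)cc2)c2cc(NC[C@@H]3CCNC3)c(F)cc2c1=O` differs from compound 2 in one place: ((pyrrolidin-3-yl)methyl)amino in place of 3-((methylamino)methyl)pyrrolidin-1-yl on an aromatic carbon. Among the measured compounds shown here, no step between measured compounds is available to set the size of this change, so the expected step of an at least 1.6-fold lower number from compound 2 to compound 4 (0.22 log units; that floor lies within the scatter) is small and may well stay within the scatter. Compound 4 is expected to give about 120000 nM, in the range 30000 nM to 400000 nM, with a real chance that this assay again reports only a limit.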

Compound 4, half-maximal inhibitory concentration: 200000 nM
Estimate against measurement, compound 4: 1.7-fold (0.22 log units) below; the measured number falls inside the stated range.
By their numbers in this assay, from the lowest: compounds 1 and 3 (each within the scatter of the next); then compound 4.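

In this assay, putting ((pyrrolidin-3-yl)methyl)amino in place of 3-((methylamino)methyl)pyrrolidin-1-yl on this aromatic carbon, ortho to a fluoro group, gives a true number for compound 4, 200000 nM. The change gives a number no higher from compound 2 to compound 4 (the limit leaves the size open) and no more. The size of this step cannot be read, because compound 2 is recorded only as a limit and not a number: the limit of > 200000 nM in this assay, at which 1 of the 4 values shown sits. Among the compounds shown here, the change therefore shows only that the number did not rise.

Going by these compounds, whether a piperazine or a longer chain ending in an amine on this same carbon would give a clearly lower number remains open.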